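Swapping one amine for another in compound 2

The source may report more compounds than this note shows. Statements on the series, on what has been measured and on what is new or still open speak of the compounds shown alone.

Two compounds have been measured so far:
Compound 1, `NC(C(=O)NCC(=O)Nc1ccc(Cl)cc1C(=O)c1ccccc1)c1ccccc1`, gives 28 mg/kg in a functional assay on the whole organism for antagonist activity, with Mus musculus as the target; on this read-out higher numbers stand for an effect only at larger amounts of compound and lower numbers for an effect already at smaller amounts.
Compound 2, `CN1CCN(CC(=O)NCC(=O)N(C)c2ccc(Cl)cc2C(=O)c2ccccc2Cl)CC1`, gives 59 mg/kg in this assay.

Within the data shown here, compound 2 thus stands highest of the two numbers; its only neighbour, compound 1, sits at a lower number, and that gap lies beyond the usual scatter of repeated measurements. Compound 3, `CC(C)NCC(=O)NCC(=O)N(C)c1ccc(Cl)cc1C(=O)c1ccccc1Cl`, has not yet been measured. It differs from compound 2 in one place: isopropylamino in place of 4-methylpiperazin-1-yl on a saturated chain carbon bound to a carbonyl carbon. Among the measured compounds shown here, no step between two measured compounds shows what such a swap does, so the expectation rests on the two values alone. A weak hint that an open amine is tolerated comes from compound 1, because compound 1 gives 28 mg/kg with a different amine in place. For compound 3 a step of a 1.5-fold lower number from compound 2 to compound 3 (0.17 log units; within the scatter) is expected, a somewhat lower number than compound 2 yet still within the scatter. The estimate for compound 3 in this assay is 40 mg/kg, ranging from 14 mg/kg to 110 mg/kg.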

Compound 3, dose for half-maximal effect: 1 mg/kg
Compound 3: middle estimate off by 40-fold (1.60 log units), on the high side; measured number below the stated range.
By their numbers in this assay, from the lowest: compound 3; then compound 1; then compound 2.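

In this assay, putting isopropylamino in place of 4-methylpiperazin-1-yl on a saturated chain carbon bound to a carbonyl carbon gives a 59-fold lower number from compound 2 to compound 3 (1.77 log units; beyond the scatter) and so shows that this place responds very strongly to the choice of amine. The swap changes several things at once: the entering group has no ring, fewer heavy atoms and a hydrogen-bond donor, whereas the leaving group has a six-membered ring and no donor, and this single step cannot separate those differences. Nothing available gives a reason for a step of this size.

Going by these compounds, whether the lower number belongs to isopropylamino alone or extends to other open amines, such as dimethylamino or tert-butylamino, remains open. A piperidin-1-yl group in the same place would help show whether the ring itself or its second nitrogen goes with the higher number of compound 2.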